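The source may hold more compounds than are shown below. What is called first, only, known or untested is meant among the compounds shown, and "the series" means these compounds.

Compound 1 `CC1=CC[C@H]2[C@H](CC[C@]2(C)O)C(C)(C)[C@@H]1CC[C@H]1[C@]2(C)CC[C@H](OC(=O)c3ccccc3)C(C)(C)O[C@H]2CC[C@@]1(C)O` is the benzoyl ester of the shared core, and in a functional assay on MDA-MB-231 cells (Homo sapiens) for antiproliferative activity, read by MTT assay, with a stated time of 72 h (a higher number here means a weaker inhibitor, a lower number a stronger inhibitor), compound 1 gives 16100 nM. Compound 2 `CC1=CC[C@H]2[C@H](CC[C@]2(C)O)C(C)(C)[C@@H]1CC[C@H]1[C@]2(C)CC[C@H](OC(=O)c3ccc([N+](=O)[O-])cc3)C(C)(C)O[C@H]2CC[C@@]1(C)O` carries the change nitro in place of hydrogen on an aromatic carbon on that ester, and in this assay compound 2 gives 8900 nM, a step of a 1.8-fold lower number from compound 1 to compound 2 (0.26 log units; within the scatter). Compound 3 `CC1=CC[C@H]2[C@H](CC[C@]2(C)O)C(C)(C)[C@@H]1CC[C@H]1[C@]2(C)CC[C@H](OC(=O)c3ccco3)C(C)(C)O[C@H]2CC[C@@]1(C)O` differs from compound 1 by furan-2-yl in place of phenyl on a carbonyl carbon; in this assay compound 3 gives 14000 nM, a step of a 1.2-fold lower number from compound 1 to compound 3 (0.06 log units; within the scatter) from compound 1 and of a 1.6-fold higher number from compound 2 to compound 3 (0.20 log units; within the scatter) from compound 2. Compound 4 `CC1=CC[C@H]2[C@H](CC[C@]2(C)O)C(C)(C)[C@@H]1CC[C@H]1[C@]2(C)CC[C@H](OC(=O)c3ccc([N+](=O)[O-])o3)C(C)(C)O[C@H]2CC[C@@]1(C)O` is not yet measured. It differs from compound 3 by nitro in place of hydrogen on an aromatic carbon, the same kind of change as that from compound 1 to compound 2, though the place differs: there the nitro sits on a six-membered aromatic ring of carbon only, para to a large group, here on a five-membered aromatic ring with one oxygen, next to the ring oxygen, two ring bonds from the ring atom that bears a large group. Since the earlier step was a 1.8-fold lower number from compound 1 to compound 2 (0.26 log units; within the scatter), the step from compound 3 to compound 4 is expected to be about a 1.8-fold lower number from compound 3 to compound 4 (0.24 log units; within the scatter). Compound 4 is therefore estimated at 8000 nM in this assay, plausibly between 4000 nM and 16000 nM.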

Compound 4, half-maximal inhibitory concentration: 11100 nM
Beside the measured number, compound 4's estimate is 1.4-fold (0.14 log units) below it; the measured number falls inside the stated range.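

In this assay, nitro in place of hydrogen on the furan ring gives a 1.3-fold lower number from compound 3 to compound 4 (0.10 log units; within the scatter), and the two steps for this change do not differ measurably: the same change on two cores in this assay, a 1.8-fold lower number (0.26 log units; within the scatter) from compound 1 to compound 2 and a 1.3-fold lower number (0.10 log units; within the scatter) from compound 3 to compound 4, 1.4-fold (0.16 log units) apart, within the scatter of two such steps. The other new steps are also small, a 1.2-fold higher number from compound 2 to compound 4 (0.10 log units; within the scatter) and a 1.5-fold lower number from compound 1 to compound 4 (0.16 log units; within the scatter), so compound 4 cannot be told apart from compound 1, compound 2 or compound 3 in this assay. The series thus shows that the nitro change behaves alike, within the scatter, on the benzoyl and furan-2-yl esters, but it does not show that the change has a real effect on either, and it says nothing about cores beyond these two.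

The compounds shown leave open whether an amine or a carboxylic acid in place of the nitro group would move the number beyond the scatter. They also leave open how an ester bearing a simple alkyl chain instead of an aromatic ring would compare.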